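Thiosemicarbazide series: cytotoxicity

The source may report more compounds than this note shows. Statements on the series, on what has been measured and on what is new or still open speak of the compounds shown alone.

Measured so far:
compound 1, `CC(=O)Nc1ccc(NC(=S)NNC(=O)c2ccncc2)cc1`: > 300000 nM
compound 2, `Cc1cccc(C)c1NC(=S)NNC(=O)c1ccncc1`: > 300000 nM
compound 3, `O=C(NNC(=S)Nc1ccc(S(=O)(=O)Nc2ncccn2)cc1)c1ccncc1`: > 300000 nM

In an ADME assay on MCF-10A cells (Homo sapiens) for cytotoxicity, read by WST assay, with a stated time of 48 h (a lower number here means a stronger inhibitor, a higher number a weaker inhibitor), compound 1 returns only a limit, > 300000 nM. Compound 2 likewise reaches only a limit, > 300000 nM. Compound 3 also sits at a limit, > 300000 nM. None of the three gives a number, because of the limit of > 300000 nM in this assay, at which 3 of the 3 values shown sit, so compound 1 cannot be placed relative to the others beyond sharing that limit.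

Compound 4, `O=C(NNC(=S)Nc1ccc(Cl)cc1)c1ccncc1`, has not been measured in this assay. Relative to compound 1 the change is chloro in place of acetamido on an aromatic carbon.

Among the compounds with values here, no measured step exists to set a scale. Given that compound 1 sits at > 300000 nM, the step of a number no higher from compound 1 to compound 4 (the limit leaves the size open) is expected to be none beyond the scatter. Compound 4 is expected to give 300000 nM, between 100000 nM and 1000000 nM, most likely again only as a limit.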

Compound 4, half-maximal inhibitory concentration: > 300000 nM
Compound 4: only a limit was reported; the forecaster's own chance of this, stated with the estimate: 80%; the middle value lies on the limit itself.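

The step from compound 1 to compound 4 cannot be read, because both compounds return only a limit: the limit of > 300000 nM in this assay, at which 4 of the 4 values shown sit.

The compounds shown leave open whether chloro and acetamido differ at all in this assay.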